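Ethyl on the hydroxy of compound 2

This account rests on a few compounds, and the source may have more. Where it says the series, first, only, none or still open, it means among the compounds named here.

Measured in an in vitro ADME assay on microsomes (Rattus norvegicus) for metabolic stability; on this read-out higher numbers stand for fast clearance and lower numbers for slow clearance:
Compound 1 `O=C(CN1CC[C@@H](NC(=O)c2ccc(Cl)s2)C1)Nc1ccc(-n2ccccc2=O)cc1F`: 79.2 mL.min-1.g-1
Compound 2 `O=C(CN1C[C@H](NC(=O)c2ccc(Cl)s2)[C@@H](O)C1)Nc1ccc(-n2ccccc2=O)cc1F`: 15.8 mL.min-1.g-1

Compound 2 holds the lower of the two numbers in this assay. The next structure, compound 3 `CCO[C@H]1CN(CC(=O)Nc2ccc(-n3ccccc3=O)cc2F)C[C@@H]1NC(=O)c1ccc(Cl)s1`, differs from it in one place: ethyl in place of hydrogen on an oxygen on a saturated carbon. This is hydroxy to ethoxy, with ethyl in place of hydrogen on an oxygen on a saturated carbon. Going by the values given here, only one measured step bears on this change: a 5.0-fold lower number from compound 1 to compound 2 (0.70 log units; beyond the scatter), which lies beyond the scatter and came with hydroxy in place of hydrogen on a saturated ring carbon. That step introduced the hydroxy, whereas the new change keeps the oxygen, so it is only a loose guide. A partial move back towards compound 1 is expected, smaller than that step. The expected step is a 2.0-fold higher number from compound 2 to compound 3 (0.31 log units; beyond the scatter). For compound 3 the estimated value is 32 mL.min-1.g-1, within an expected range of 14 mL.min-1.g-1 to 75 mL.min-1.g-1.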

Compound 3, intrinsic clearance in microsomes: 68.3 mL.min-1.g-1
Estimate against measurement, compound 3: 2.1-fold (0.33 log units) below; the range from low to high includes it.
By their numbers in this assay, from the lowest: compound 2; then compounds 3 and 1 (each within the scatter of the next).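

In this assay ethyl in place of hydrogen on this oxygen gives a 4.3-fold higher number from compound 2 to compound 3 (0.64 log units; beyond the scatter) and so takes away most of what the hydroxy had brought, which shows that keeping an oxygen at this position is not enough to hold the low number. Against the unsubstituted ring carbon, ethoxy gives a 1.2-fold lower number from compound 1 to compound 3 (0.06 log units; within the scatter) and leaves compound 3 on a level with compound 1 on this read-out, so among these three compounds only the free hydroxy stands apart. Nothing shown here accounts for this difference between hydroxy and ethoxy.

As far as these compounds go, whether a smaller methoxy would sit nearer compound 2 or nearer compound 3 stays open. So does the outcome with an amine or a fluorine in place of the hydroxy on the same carbon.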